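The compounds below may be only part of what the source reports. "The series", "measured", "known", "first", "only" and "open" are said of these compounds alone.

Compound 1 `COc1cccc(N2C(=O)COc3ccc(-c4cnc(Cl)c(NS(=O)(=O)c5ccc(F)cc5)c4)cc32)c1`: in a functional assay on HCT-116 cells (Homo sapiens) for antiproliferative activity, read by MTT assay, with a stated time of 72 h (a higher number here means a weaker inhibitor, a lower number a stronger inhibitor), compound 1 gives > 40000 nM.
Compound 2 `O=C1COc2ccc(-c3cccc(NS(=O)(=O)c4ccc(F)cc4)c3)cc2N1`: in this assay compound 2 gives > 40000 nM.
Compound 3 `O=C1COc2ccc(-c3cnc(Cl)c(NS(=O)(=O)c4ccc(F)cc4)c3)cc2N1`: in this assay compound 3 gives > 40000 nM.

The value of compound 1 is a limit of the assay, not a number. The value of compound 2 is likewise a limit. The value of compound 3 is also a limit. Compound 3 and compound 1 differ in one place: 3-methoxyphenyl in place of hydrogen on an amide-type nitrogen in a ring. The step that the two limits leave unreadable from compound 3 to compound 1 cannot be read because both values sit at the limit of > 40000 nM in this assay, at which 3 of the 3 values shown sit.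

Compound 4 `COc1cccc(N2C(=O)COc3ccc(-c4cccc(NS(=O)(=O)c5ccc(F)cc5)c4)cc32)c1` has not been measured. It differs from compound 2 by 3-methoxyphenyl in place of hydrogen on an amide-type nitrogen in a ring, the same change at the same place. How the core of compound 2 differs from the core of compound 3 is not broken down here.

The expected step is a step that the limit leaves unreadable from compound 2 to compound 4, resting on compound 3 and compound 1 both sitting at the limit of > 40000 nM in this assay, at which 3 of the 3 values shown sit. Compound 4 is expected to give about 50000 nM, most likely again only a limit.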

Compound 4, half-maximal inhibitory concentration: > 40000 nM
Compound 4: a limit, no number (the forecaster's own chance of this, stated with the estimate: 80%); the middle value lies beyond the limit too.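

Compound 2 and compound 4 both give limits rather than numbers, so no step can be read between them: the limit of > 40000 nM in this assay, at which 4 of the 4 values shown sit.

The compounds shown leave open whether 3-methoxyphenyl in place of hydrogen on the amide-type nitrogen changes antiproliferative activity at all.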